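A cyclic amine in place of ethylamino: series notes

A few compounds are considered here, and "the series" means these few. Any claim that something is new, unique, unknown or untested is made for them only; others in the source may bear on it.

Measured compounds:
compound 1 `CNc1nc(NCc2ccc(C(=O)NC3CCN(Cc4ccc(F)cc4)CC3)cc2)c2cc(C)ccc2n1`, in a functional assay on SW480 cells (Homo sapiens) for inhibition, read by luminescence and resazurin assay, with a stated time of 3 days (on this read-out lower numbers stand for stronger inhibition and higher numbers for weaker inhibition), compound 1 gives 1300 nM
compound 2 `CCCNc1nc(NCc2ccc(NC(=O)c3ccc(F)cc3)cc2)c2ccccc2n1`, in this assay compound 2 gives 2000 nM
compound 3 `CCNc1nc(NCc2ccc(NC(=O)c3ccc(F)cc3)cc2)c2ccccc2n1`, in this assay compound 3 gives 2300 nM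

Compound 3 sits within the scatter of both other compounds, so no order among the three can be read from these numbers. Going by the values given here, the single measured step, a 1.2-fold higher number from compound 2 to compound 3 (0.06 log units; within the scatter), shortens the alkyl chain on the amino group and stays within the scatter. Compound 4 `CN1CCN(c2nc(NCc3ccc(NC(=O)c4ccc(F)cc4)cc3)c3ccccc3n2)CC1` is not yet measured. It differs from compound 3 by 4-methylpiperazin-1-yl in place of ethylamino on an aromatic carbon. Among the compounds with values here, no measured step covers the exchange of an open-chain amino group for a ring at this position; the only change seen there was small. Compound 4 is therefore expected to show a 1.3-fold higher number from compound 3 to compound 4 (0.12 log units; within the scatter) in this assay, with wide uncertainty. The estimate for compound 4 is 3000 nM, from 1000 nM to 9000 nM.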

Compound 4, half-maximal inhibitory concentration: 2500 nM
The estimate for compound 4 lay 1.2-fold (0.08 log units) above the measured number; measured number inside the range.
By their numbers in this assay, from the lowest: compounds 1, 2, 3 and 4 (each within the scatter of the next).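

In this assay a ring on this aromatic carbon reads no differently from the open chains, with a 1.1-fold higher number from compound 3 to compound 4 (0.04 log units; within the scatter) for the exchange of ethylamino and a 1.3-fold higher number from compound 2 to compound 4 (0.10 log units; within the scatter) for the exchange of propylamino. Ethylamino carries a hydrogen-bond donor and 4-methylpiperazin-1-yl carries none, yet the number stays within the scatter. No supporting data bear on this result.

Open, as far as these compounds go, is whether piperazine without the methyl, morpholine or a longer chain at this position would move the number beyond the scatter. Also open, from the compounds shown here alone, is whether this tolerance holds on the core of compound 1.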